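The step from compound 3 to compound 4

The source may hold more compounds than are shown below. What is called first, only, known or untested is meant among the compounds shown, and "the series" means these compounds.

Measured so far in a functional assay on HT-29 cells (Homo sapiens) for cytotoxicity, read by MTT assay, with a stated time of 72 h; a higher number here means a weaker inhibitor, a lower number a stronger inhibitor:
compound 1 `Cc1ccc(NC(=O)CN2CCN(c3nnc(Cc4ccncc4)c4ccccc34)CC2)c(C)c1` gives 1930 nM
compound 2 `O=C(CN1CCN(c2nnc(Cc3ccccc3)c3ccccc23)CC1)Nc1ccc(F)c(C(F)(F)F)c1` gives 4590 nM
compound 3 `O=C(CN1CCN(c2nnc(Cc3ccccc3)c3ccccc23)CC1)Nc1ccc(F)c(F)c1` gives 9510 nM

Of these three, compound 3 has the highest number (9510 nM), which makes it the weakest inhibitor so far. Compound 2 lies nearest to it and compound 1 furthest away. The next compound, compound 4 `O=C(CN1CCN(c2nnc(Cc3ccccc3)c3ccccc23)CC1)Nc1cc(C(F)(F)F)ccc1Cl`, differs from compound 3 on the anilide side alone: 2-chloro-5-(trifluoromethyl)phenyl in place of 3,4-difluorophenyl on an amide-type nitrogen. In words, 2-chloro-5-(trifluoromethyl)phenyl takes the place of 3,4-difluorophenyl on an amide-type nitrogen.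

Going by the values given here, only one measured step bears directly on this change. It is a 2.1-fold higher number from compound 2 to compound 3 (0.32 log units; beyond the scatter), with fluoro in place of trifluoromethyl on an aromatic carbon. Read in reverse, that step links a trifluoromethyl group on this ring to the lower number, and compound 4 carries such a group too. Compound 1 differs from the others in more than one place and gives no clean comparison. Among the compounds with values here, no measured step covers the 2-chloro part of the new group, so the expectation stays loose.

What is expected in this assay is a 2.1-fold lower number from compound 3 to compound 4 (0.32 log units; beyond the scatter), a modest step towards a stronger inhibitor. For compound 4 the estimated value is 4500 nM, with an expected range from 1800 nM to 11000 nM (an estimate, not a measurement).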

Compound 4, half-maximal inhibitory concentration: 66800 nM
Beside the measured number, compound 4's estimate is 15-fold (1.17 log units) below it; the measured number lies above the stated range.
By their numbers in this assay, from the lowest: compound 1; then compound 2; then compound 3; then compound 4.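

In this assay, the group on the amide-type nitrogen proves able to shift the number much further than the earlier fluoro and trifluoromethyl exchange suggested: the change brings a 7.0-fold higher number from compound 3 to compound 4 (0.85 log units; beyond the scatter), and the comparison with the other trifluoromethyl anilide brings a 15-fold higher number from compound 2 to compound 4 (1.16 log units; beyond the scatter). A trifluoromethyl group on this ring therefore does not go with a lower number by itself, since compound 2 and compound 4 both carry one and lie far apart, while compound 3 has none and still gives the lower number of the pair it forms with compound 4. Nothing measured on these compounds explains the rise.

The 2-chloro-5-(trifluoromethyl)phenyl group differs from 4-fluoro-3-(trifluoromethyl)phenyl both in its chlorine and in the placing of its trifluoromethyl, so the compounds shown cannot say which of the two goes with the higher number. Also open, as far as these compounds go, is how a simpler anilide, such as a 2-chlorophenyl group alone or a phenyl group bearing a methoxy or a carboxylic acid, would stand in this assay.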